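The source may report more compounds than this note shows. Statements on the series, on what has been measured and on what is new or still open speak of the compounds shown alone.

In an ADME assay (Rattus norvegicus, strain Wistar Han) for metabolic stability (on this read-out lower numbers stand for a shorter-lived compound and higher numbers for a longer-lived compound), compound 1 `CCn1c(-c2cnc(C)nc2)nc2c(O[C@H]3CCN(C(=O)C4CC4)C3)ncnc21` gives 1.8 h, the second highest of the three numbers recorded so far. Compound 2 `CCn1c(-c2cnc(C)nc2)nc2c(N[C@H]3CCN(C(=O)C4CCOC4)C3)ncnc21` gives 0.6 h in this assay, a lower number than compound 1, while compound 3 `CCn1c(-c2ccc(C(F)(F)F)nc2)nc2c(O[C@H]3CCN(C(=O)c4cocn4)C3)ncnc21` gives 6 h, the highest of the three; both gaps to compound 1 lie beyond the usual scatter. Compound 4 `CCn1c(-c2cnc(C)nc2)nc2c(O[C@H]3CCN(C(=O)C4CC(F)(F)C4)C3)ncnc21` has not yet been measured. It differs from compound 1 in one place: 3,3-difluorocyclobutyl in place of cyclopropyl on a carbonyl carbon. Within the data shown here, no measured pair shows this change, so its effect cannot be read from the data. One expects the step of a 1.4-fold higher number from compound 1 to compound 4 (0.14 log units; within the scatter) to be modest, a slight rise at most and possibly none beyond the scatter. Compound 4 is therefore estimated at 2.5 h, within a range from 1 h to 6 h.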

Compound 4, half-life: 1.4 h
Compound 4: the middle estimate sits 1.8-fold (0.25 log units) above what was measured; the measured number falls inside the stated range.
By their numbers in this assay, from the lowest: compound 2; then compounds 4 and 1 (each within the scatter of the next); then compound 3.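

In this assay, among these compounds, 3,3-difluorocyclobutyl in place of cyclopropyl on a carbonyl carbon gives a 1.3-fold lower number from compound 1 to compound 4 (0.11 log units; within the scatter) and is the first single change that can be read at this position. Here, going from three heavy atoms to six in this group does not separate the two compounds beyond the scatter. Nothing given here accounts for this result. The compounds shown leave open whether an open chain such as isopropyl or a ring holding an amine such as azetidine, placed on that carbonyl carbon, would also stay within the scatter of compound 1.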